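The compounds below may be only part of what the source reports. "The series", "measured", "known", "first", "only" and "open" are said of these compounds alone.

Compound 3, `CCc1ncnc(NC(CC)c2ccc(Oc3ccc(F)cc3)cc2)c1Br`, is one of three close relatives examined in an ADME assay on HEK-293T cells (Homo sapiens) for cytotoxicity, with a stated time of 48 h; a higher number here means that more compound is tolerated, a lower number that less compound is tolerated. In this assay compound 3 reaches only a limit, > 10000 nM. Its two companions sit at the same point. Compound 1, `CCCc1cc(NC(CC)c2ccc(Oc3ccc(F)cc3)cc2)ncn1`, gives in this assay the limit > 10000 nM. Compound 2, `CCC(Nc1cc(COC)ncn1)c1ccc(Oc2ccc(F)cc2)cc1`, likewise gives in this assay the limit > 10000 nM. All three share (the limit of > 10000 nM in this assay, at which 3 of the 3 values shown sit), and so the three steps among them cannot be read: a step that the two limits leave unreadable from compound 1 to compound 2, a step that the two limits leave unreadable from compound 1 to compound 3 and a step that the two limits leave unreadable from compound 2 to compound 3.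

Compound 4, `CCC(Nc1nc(C)nc(Cl)c1N)c1ccc(Oc2ccc(F)cc2)cc1`, has not yet been measured. It differs from compound 3 in one place: 5-amino-6-chloro-2-methylpyrimidin-4-yl in place of 5-bromo-6-ethylpyrimidin-4-yl on an amine nitrogen. Going by the values given here, the measured steps that bear on this change are the exchanges on the amine nitrogen between compound 1 and compound 3 and between compound 2 and compound 3, but none of them moved any compound off the limit, so they give no size for the step in this assay. The expectation is that compound 4 also stays at the limit, with no step beyond the scatter, the estimated step being a step that the limit leaves unreadable from compound 3 to compound 4. Compound 4 is expected to give about 15000 nM in this assay, within a range of 7000 nM to 30000 nM.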

Compound 4, half-maximal cytotoxic concentration: > 10000 nM
Compound 4 gave a limit, no number; the forecaster's own chance of this, stated with the estimate: 85%; the middle value does not contradict the limit.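

Compound 4 also stops at a limit in this assay, so its steps to compound 1, compound 2 and compound 3 cannot be read, and all four compounds stand together: the limit of > 10000 nM in this assay, at which 4 of the 4 values shown sit. The compounds shown leave open where the half-maximal cytotoxic concentration of each one lies, and whether any exchange on the amine nitrogen changes it.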